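Moving a Hydroxyl Group Around a Shared Core

A few compounds are considered here, and "the series" means these few. Any claim that something is new, unique, unknown or untested is made for them only; others in the source may bear on it.

Compound 1 `Oc1cccc(-c2cc(-c3cccc(OC(F)(F)F)c3)cc(-c3ccccc3O)n2)c1` carries a 3-hydroxyphenyl group on its core. In a functional assay on DU-145 cells (Homo sapiens) for inhibition (on this read-out higher numbers stand for weaker inhibition and lower numbers for stronger inhibition), compound 1 reaches only a limit, > 50000 nM. Compound 2 `Oc1ccc(-c2cc(-c3cccc(OC(F)(F)F)c3)cc(-c3ccccc3O)n2)cc1` carries a 4-hydroxyphenyl group in that place. In this assay compound 2 likewise reaches only a limit, > 50000 nM. The change between them is 4-hydroxyphenyl in place of 3-hydroxyphenyl on an aromatic carbon, and the step that the two limits leave unreadable from compound 1 to compound 2 stays unreadable because the limit of > 50000 nM in this assay, at which 3 of the 3 values shown sit, covers both compounds.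

Compound 3 `Oc1cccc(-c2cc(-c3ccc(OC(F)(F)F)cc3)cc(-c3cccc(O)c3)n2)c1` has a core of its own; how it differs from the core of compound 1 is not broken down here. In this assay compound 3 also reaches only a limit, > 50000 nM. Compound 4 `Oc1ccc(-c2cc(-c3ccc(OC(F)(F)F)cc3)cc(-c3cccc(O)c3)n2)cc1` is not yet measured. It arises from compound 3 by 4-hydroxyphenyl in place of 3-hydroxyphenyl on an aromatic carbon, the same kind of change as in the first pair, though the surroundings differ: here the place is meta to a 3-hydroxyphenyl group rather than meta to a 2-hydroxyphenyl group. Among the measured compounds shown here, because the limit of > 50000 nM in this assay, at which 3 of the 3 values shown sit, holds for every value so far, compound 4 is expected to stay at the limit too, the expected step that the limit leaves unreadable from compound 3 to compound 4 meaning no measurable gain. The estimate for compound 4 in this assay is 100000 nM, between 50000 nM and 300000 nM.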

Compound 4, half-maximal inhibitory concentration: 18100 nM
The estimate for compound 4 lay 5.5-fold (0.74 log units) above the measured number, and the stated range ends above it.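

In this assay the change from 3-hydroxyphenyl to 4-hydroxyphenyl gives an at least 2.7-fold lower number from compound 3 to compound 4 (0.44 log units; beyond the scatter), so on the core of compound 3 this shift of the hydroxyl group produces a step beyond the usual scatter. On the core of compound 1 the same change cannot be read, and the data therefore cannot show whether the step carries over from one core to the other, since both compounds of that pair sit at a limit: the limit of > 50000 nM in this assay, at which 3 of the 4 values shown sit. The series thus offers one readable step on one core, which neither confirms nor contradicts a transfer, and its printed size is only a minimum.

The compounds shown leave open whether the step would survive if the hydroxyl group of the 4-hydroxyphenyl group gave way to an amine or a carboxylic acid. Also open, on these data alone, is whether a second 4-hydroxyphenyl group, in place of the remaining 3-hydroxyphenyl group, would lower the number further in this assay.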